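The compounds below may be only part of what the source reports. "The series", "measured", "known", "first", "only" and "open" are said of these compounds alone.

Three analogues built on a shared core differing only in the group on the saturated chain carbon bound to an oxygen on an aromatic ring have been measured in a functional assay on spleen for antagonist activity at Alpha-1B adrenergic receptor (Rattus norvegicus); a higher number here means a more potent compound, by a factor of ten per unit of this negative logarithm, a lower number a less potent compound. Compound 1 `COc1cccc(OC)c1OCCNCCOc1ccccc1OCc1cccc(Cl)c1` gives 7.93 in this assay. Compound 2 `COc1cccc(OC)c1OCCNCCOc1ccccc1OCc1ccc(Cl)cc1` gives 8.06, and compound 3 `COc1cccc(OC)c1OCCNCCOc1ccccc1OCc1ccccc1[N+](=O)[O-]` gives 8.56. Compound 3 stands highest of the three numbers: the step of a number 0.50 log units higher from compound 2 to compound 3 (beyond the scatter) is beyond the scatter, as is the step of a number 0.63 log units higher from compound 1 to compound 3 (beyond the scatter), whereas the step of a number 0.13 log units higher from compound 1 to compound 2 (within the scatter) lies within it.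

Compound 4 `COc1cccc(OC)c1OCCNCCOc1ccccc1OCc1cccc([N+](=O)[O-])c1` differs from compound 3 by 3-nitrophenyl in place of 2-nitrophenyl on a saturated chain carbon bound to an oxygen on an aromatic ring. Going by the values given here, no measured step moves a nitro group from one ring position to another. Among the compounds with values here, the only step that moves a substituent around the ring is the one from compound 1 to compound 2, a chloro shift, and that step stays within the scatter. As far as these compounds go, both steps that bring the 2-nitrophenyl in are modest gains, and whether the gain depends on the nitro sitting as 2-nitrophenyl rather than 3-nitrophenyl is unknown. Compound 4 is therefore expected to sit near compound 3, with a slight expected easing of a number 0.36 log units lower from compound 3 to compound 4 (beyond the scatter) in this assay. Compound 4 is estimated at 8.2, within a range from 7.7 to 8.7.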

Compound 4, negative logarithm of the antagonist equilibrium constant: 8.74
Estimate against measurement, compound 4: 0.54 log units below; the measured number lies above the stated range.
By their numbers in this assay, from the lowest: compounds 1 and 2 (each within the scatter of the next); then compounds 3 and 4 (each within the scatter of the next).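

In this assay, the shift from 2-nitrophenyl to 3-nitrophenyl on a saturated chain carbon bound to an oxygen on an aromatic ring comes out as a step of (a number 0.18 log units higher from compound 3 to compound 4 (within the scatter)), so the gain seen with compound 3 does not hang on the nitro sitting as 2-nitrophenyl. Going by these compounds alone, the two nitro compounds now read alike, as the two chloro compounds do, and the split at this place follows the substituent rather than its ring position: 3-nitrophenyl in place of 4-chlorophenyl gives (a number 0.68 log units higher from compound 2 to compound 4 (beyond the scatter)), and the direct swap of nitro for chloro on an aromatic carbon gives (a number 0.81 log units higher from compound 1 to compound 4 (beyond the scatter)), with no compound among the four going against this. Nothing measured here explains why the nitro compounds read as they do.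

Open, as far as these compounds go, is whether 4-nitrophenyl at this place would read with compounds 3 and 4, and whether 2-chlorophenyl would stay with compounds 1 and 2. Also open, from the compounds shown here alone, is whether the gain is particular to nitro, or whether a nitrile, an amine or a carboxylic acid on the same phenyl would match it.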